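Replacing an Ethyl Ester with a Longer Branched Chain

This account rests on a few compounds, and the source may have more. Where it says the series, first, only, none or still open, it means among the compounds named here.

Measured compounds:
compound 1, `CC(C)c1cccc(C(C)C)c1NC(=O)CC(=O)Oc1c(-c2ccccc2)cccc1-c1ccccc1`: 67 nM
compound 2, `CCOC(=O)CC(=O)Nc1c(C(C)C)cccc1C(C)C`: 1800 nM

In an assay on microsomes from intestine for inhibition of acyl-CoA:cholesterol acyltransferase (Oryctolagus cuniculus) (a lower number here means a stronger inhibitor, a higher number a weaker inhibitor), compound 1 gives 67 nM. Compound 2 gives 1800 nM in this assay, the highest of the two numbers; its nearest neighbour is compound 1, whose much lower number lies beyond the scatter. Compound 3, `CCCCCC(C)OC(=O)CC(=O)Nc1c(C(C)C)cccc1C(C)C`, differs from compound 2 in one place: pentyl in place of hydrogen on a saturated chain carbon bound to an oxygen next to a carbonyl group and a saturated chain carbon. Within the data shown here, no measured pair covers this change, so the expectation rests on compound 1, which shows that far lower numbers are reachable in this assay. The step from compound 2 to compound 3 is expected to lower the number beyond the scatter, a 4.5-fold lower number from compound 2 to compound 3 (0.65 log units; beyond the scatter). Compound 3 is estimated at 400 nM, between 100 nM and 1500 nM.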

Compound 3, half-maximal inhibitory concentration: 27 nM
The estimate for compound 3 lay 15-fold (1.17 log units) above the measured number; measured number outside the range, below it.
By their numbers in this assay, from the lowest: compound 3; then compound 1; then compound 2.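

In this assay, changing ethoxy to (1-methylhexyl)oxy gives a 67-fold lower number from compound 2 to compound 3 (1.82 log units; beyond the scatter), a large step. This is the first pair shown that differs in one place, and it shows that this end of the molecule accepts a much bigger chain without a ring, with the number falling rather than rising. Nothing measured here explains the size of this step.

The compounds shown leave open whether the branch or simply the added carbons carry the gain. They also leave open how a longer chain or an amine at this place would fare.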